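Replacing 1H-indol-3-yl with 3,4-dichlorophenyl

The compounds below may be only part of what the source reports. "The series", "measured", "known", "first", "only" and "open" are said of these compounds alone.

In an ADME assay on HEK293 cells (Homo sapiens) for cytotoxicity, read by CellTiter-Glo and resazurin assay, with a stated time of 72 h (a higher number here means that more compound is needed for the effect, a lower number that less compound is needed), compound 3 (`CC(C)N(Cc1cccc(OCCCCCC(=O)O)c1)C(=O)c1ccc(-c2c[nH]c3ccccc23)cc1`) gives > 26000 nM as its reading, which is a limit and not a number. Compound 1 (`CCOc1cccc(-c2ccc(C(=O)N(Cc3cccc(OCCCCCC(=O)O)c3)C(C)C)cc2)c1`) gives > 20800 nM as its reading, also a limit. Compound 2 (`CC(C)N(Cc1cccc(OCCCCCC(=O)O)c1)C(=O)c1ccc(-c2cccc(OC(F)(F)F)c2)cc1`) gives > 26000 nM as its reading, again a limit. Going by the values given here, no compound has a number so far, and the record consists of the limit of > 20800 nM in this assay, at which 1 of the 3 values shown sits, together with the limit of > 26000 nM in this assay, at which 2 of the 3 values shown sit, and nothing else.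

Compound 4 (`CC(C)N(Cc1cccc(OCCCCCC(=O)O)c1)C(=O)c1ccc(-c2ccc(Cl)c(Cl)c2)cc1`) carries 3,4-dichlorophenyl in place of 1H-indol-3-yl on an aromatic carbon. The closest precedents are the two exchanges of the group at that same carbon (a step that the two limits leave unreadable from compound 1 to compound 3; a step that the two limits leave unreadable from compound 2 to compound 3). The change on the oxygen (a step that the two limits leave unreadable from compound 1 to compound 2) lies elsewhere in the structure and adds little. None of these three steps has a readable size, so no shift beyond the scatter is expected in this assay and no direction can be given. The expected step is a number no higher from compound 3 to compound 4 (the limit leaves the size open) by estimate. For compound 4 the estimated value is 26000 nM (range 10000 nM to 50000 nM) and another limit is the most likely report.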

Compound 4, half-maximal effective concentration: > 26000 nM
Compound 4 was reported as a limit; the forecaster's own chance of this, stated with the estimate: 75%; the middle value lies on the limit itself.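

In this assay compound 4 gives > 26000 nM, which is a limit and not a number. The steps to compound 4 from compound 1, compound 2 and compound 3 cannot be read. The compounds shown leave open what half-maximal effective concentration any of the four would reach, and whether changing the group at this aromatic carbon shifts it.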